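This account rests on a few compounds, and the source may have more. Where it says the series, first, only, none or still open, it means among the compounds named here.

Compound 1 `O=C(CCCCC1CCSS1)Nc1ccccn1` and compound 2 `O=C(CCCCC1CCSS1)Nc1ccc(Cl)cn1` share one core, while compound 3 `O=C(CCCCC(S)CCS)Nc1ccccc1` and the still unmeasured compound 4 `O=C(CCCCC(S)CCS)Nc1ccccc1Cl` share another; how the core of compound 1 differs from that of compound 3 is not broken down here. In a functional assay on NCI-H460 cells (Homo sapiens) for inhibition, read by MTT assay, with a stated time of 24 h, tested at 100 ug/mL (on this read-out lower numbers stand for less inhibition of growth and higher numbers for more inhibition of growth at the one concentration tested), compound 1 gives 39.3%, compound 2 gives 58.6% and compound 3 gives 25.4%. The change chloro in place of hydrogen on an aromatic carbon brought a number 19.3 percentage points higher from compound 1 to compound 2 (beyond the scatter). The change chloro in place of hydrogen on an aromatic carbon is the same kind of change, but the place differs: in compound 2 the chloro sits on a ring with one nitrogen, two atoms from the ring nitrogen and para to a large group, whereas in compound 4 it sits on a ring of carbon only, ortho to a large group. A step of a number 12.6 percentage points higher from compound 3 to compound 4 (beyond the scatter) is expected, resting on the earlier step of a number 19.3 percentage points higher from compound 1 to compound 2 (beyond the scatter) with some allowance for the different place. Compound 4 is therefore estimated at 38%, between 20% and 56%.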

Compound 4, percent growth inhibition at one concentration: 12.1%
Compound 4: the middle estimate sits 25.9 percentage points above what was measured; the whole stated range lies above it.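

In this assay, chloro in place of hydrogen on an aromatic carbon brought a number 13.3 percentage points lower from compound 3 to compound 4 (beyond the scatter), so the gain seen on the core of compound 1 did not carry over to the core of compound 3, and the two steps run in opposite directions: the same change on two cores in this assay, a number 19.3 percentage points higher (beyond the scatter) from compound 1 to compound 2 and a number 13.3 percentage points lower (beyond the scatter) from compound 3 to compound 4, 32.6 percentage points apart, beyond the scatter of two such steps

This does not show that the core alone decides the outcome, since the two pairs also differ in their ring and in where the chloro sits. With one pair on each core, the result is a warning against carrying the change across, not a rule for the series.

As far as these compounds go, it remains open how chloro would act at matching places on both cores, and whether a fluoro or a methoxy group would follow the same direction.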